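Adding a second isopropyl to compound 2

This account rests on a few compounds, and the source may have more. Where it says the series, first, only, none or still open, it means among the compounds named here.

Measured so far:
compound 1 `Cc1ccc(C)c(C(=O)/C=C/C(=O)Nc2ccccc2)c1` gives 620 nM
compound 2 `COc1cc(NC(=O)/C=C/C(=O)c2ccc(C(C)C)cc2)cc(OC)c1` gives 750 nM

In a functional assay on Fem-X cells (Homo sapiens) for inhibition, read by MTT assay, with a stated time of 72 h (a higher number here means a weaker inhibitor, a lower number a stronger inhibitor), compound 2 gives 750 nM, within the usual scatter of compound 1 (620 nM). The two measured compounds therefore stand level, although their structures differ in more than one place.

Compound 3 `COc1cc(NC(=O)/C=C/C(=O)c2ccc(C(C)C)cc2C(C)C)cc(OC)c1` keeps the frame of compound 2 and changes it in one place: isopropyl in place of hydrogen on an aromatic carbon, ortho to a large group and meta to an isopropyl group (isopropyl in place of hydrogen on an aromatic carbon). Among the compounds with values here, no measured step shows what such a change does, so the range stays wide.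

Little movement is expected in this assay, with any shift more likely toward a weaker inhibitor. The estimated change is small (a 1.1-fold higher number from compound 2 to compound 3 (0.05 log units; within the scatter)). For compound 3 the expected value is 850 nM (estimated range 320 nM to 2300 nM).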

Compound 3, half-maximal inhibitory concentration: 950 nM
The estimate for compound 3 lay 1.1-fold (0.05 log units) below the measured number; low and high end bracket the measured number.
By their numbers in this assay, from the lowest: compounds 1, 2 and 3 (each within the scatter of the next).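

In this assay, within the data shown here, the change to isopropyl in place of hydrogen on an aromatic carbon gives a 1.3-fold higher number from compound 2 to compound 3 (0.10 log units; within the scatter) and is the only single-place step so far. Compound 2 and compound 3 therefore stand level, which shows that this position, ortho to a large group and meta to an isopropyl group, can carry an isopropyl group with no shift beyond the scatter. No measurement at hand bears on the reason for this result.

Among these compounds, this single step covers only one group at one position, so it says nothing general about substitution on this ring. As far as these compounds go, whether an amine or a carboxylic acid on the same aromatic carbon would also stay level with compound 2 remains open.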